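The compounds below may be only part of what the source reports. "The series", "measured", "known", "first", "only" and "open" are said of these compounds alone.

Compound 1 `CCC(=O)N1CC[C@H](Nc2ncnc3c2nc(-c2cnn(CC)c2C)n3C)C1` gives 4 L/kg
Compound 2 `CCn1ncc(-c2nc3c(N[C@H]4CCN(C(=O)C5CC5)C4)ncnc3n2C)c1C` gives 4 L/kg
Compound 3 `CCn1ncc(-c2nc3c(O[C@H]4CCN(C(=O)C5CC5)C4)ncnc3n2C)c1C` gives 2 L/kg

These figures come from an ADME assay (Rattus norvegicus, strain Wistar Han) for pharmacokinetics (a lower number here means that more of the compound stays in the plasma, a higher number that more of the compound sits outside the plasma), and there compound 2 stands level with compound 1, while compound 3 (2 L/kg) lies within the scatter of both. The step followed here leads to compound 4 `CCn1ncc(-c2nc3c(N[C@H]4CCN(C(=O)C5CCOCC5)C4)ncnc3n2C)c1C` and puts oxan-4-yl in place of cyclopropyl on a carbonyl carbon while the rest of the molecule stays the same. For the measured compounds named here, the one measured step at this kind of place, cyclopropyl in place of ethyl, reads no change at the digits printed from compound 1 to compound 2 (within the scatter) and so shows no shift beyond the scatter. Going by the values given here, no measured compound carries oxan-4-yl, so this guide is thin and the range must stay wide. No step beyond the scatter is expected, and the estimated step reads a 1.3-fold lower number from compound 2 to compound 4 (0.12 log units; within the scatter) in this measurement. For compound 4 the expected value in this assay is 3 L/kg within an estimated range (1.5 L/kg to 6 L/kg).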

Compound 4, volume of distribution: 3 L/kg
For compound 4 middle estimate and measured number coincide at the digits printed; the range from low to high includes it.
By their numbers in this assay, from the lowest: compounds 3, 4, 1 and 2 (each within the scatter of the next).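

With oxan-4-yl on the carbonyl carbon, this assay reads a 1.3-fold lower number from compound 2 to compound 4 (0.12 log units; within the scatter) and a 1.3-fold lower number from compound 1 to compound 4 (0.12 log units; within the scatter). For the compounds shown here, the earlier compounds carried only ethyl or cyclopropyl at this place, so this is the first sign that a six-membered ring with a hetero atom can sit here without a shift beyond the scatter. No supporting data bear on why the number holds steady. On these data alone, whether an amine or a carboxylic acid on this carbonyl carbon would move the number beyond the scatter stays open.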